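The compounds below may be only part of what the source reports. "The series", "measured", "known", "first", "only" and "open" are said of these compounds alone.

Measured in a functional assay on HCT-116 cells (Homo sapiens) for inhibition; on this read-out lower numbers stand for stronger inhibition and higher numbers for weaker inhibition:
- compound 1 `CCNC(=O)c1noc(-c2cc(C(C)C)c(O)cc2O)c1-c1cc(CNC(=O)CC)no1`: 78 nM
- compound 2 `CCCN(CCC)Cc1cc(-c2c(C(=O)NCC)noc2-c2cc(C(C)C)c(O)cc2O)on1`: 183 nM
- compound 3 `CCNC(=O)c1noc(-c2cc(C(C)C)c(O)cc2O)c1-c1cc(CN2CCCCC2)no1`: 93 nM

Compound 3 is not separated from either neighbour: a 1.2-fold higher number from compound 1 to compound 3 (0.08 log units; within the scatter), and a 2.0-fold lower number from compound 2 to compound 3 (0.29 log units; within the scatter). Compound 4 `CCNC(=O)c1noc(-c2cc(C(C)C)c(O)cc2O)c1-c1cc(C(=O)NC)no1` has methylcarbamoyl in place of (piperidin-1-yl)methyl on an aromatic carbon of a five-membered aromatic ring with 1 nitrogen and 1 oxygen: methylcarbamoyl in place of (piperidin-1-yl)methyl on an aromatic carbon. The measured steps all exchange groups on the saturated chain carbon, and the only one beyond the scatter is a 2.3-fold higher number from compound 1 to compound 2 (0.37 log units; beyond the scatter). For the measured compounds named here, no measured compound lacks that chain carbon, so the evidence is indirect and the range stays wide. The expected change is none beyond the scatter: a 1.0-fold lower number from compound 3 to compound 4 (0.01 log units; within the scatter). The estimated value for compound 4 is 90 nM, with an expected range of 30 nM to 300 nM.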

Compound 4, half-maximal inhibitory concentration: 124 nM
Compound 4: middle estimate off by 1.4-fold (0.14 log units), on the low side, within the range that was stated.
By their numbers in this assay, from the lowest: compounds 1, 3, 4 and 2 (each within the scatter of the next, the first and the last beyond it).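

In this assay, methylcarbamoyl on the aromatic carbon, which has no saturated chain carbon, stays within the scatter of all three earlier groups (a 1.3-fold higher number from compound 3 to compound 4 (0.12 log units; within the scatter); a 1.5-fold lower number from compound 2 to compound 4 (0.17 log units; within the scatter); a 1.6-fold higher number from compound 1 to compound 4 (0.20 log units; within the scatter)). For the compounds shown here, this gives the first direct reading that a group without that chain carbon and without a ring can sit at this position with no separable change in the number. No measured evidence bears on the reason for this. As far as these compounds go, it remains open whether a carboxylic acid or a longer chain on the amide nitrogen would stay in this range. A bare hydrogen at this aromatic carbon also remains untested in the compounds shown.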